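A few compounds are considered here, and "the series" means these few. Any claim that something is new, unique, unknown or untested is made for them only; others in the source may bear on it.

Measured so far:

Compound 1, `CN(CC1=CC[C@H]2C[C@@H]1C2(C)C)Cc1ccc(Cl)cc1`, gives 2510 nM in an assay on HEK293 cells for displacement of a labelled ligand from C-X-C chemokine receptor type 3 (Homo sapiens); a higher number here means a weaker inhibitor, a lower number a stronger inhibitor.
Compound 2, `CN(CC1=CC[C@H]2C[C@@H]1C2(C)C)Cc1ccc(-c2cccc(F)c2)cc1`, gives 2510 nM in this assay.

For the measured compounds named here, compound 2 stands level with compound 1 on these numbers; the one measured step, no change at the digits printed from compound 1 to compound 2 (within the scatter), is the change that replaced chloro with 3-fluorophenyl on the aromatic carbon, and it left the read-out where it was. Compound 3, `CN(CC1=CC[C@H]2C[C@@H]1C2(C)C)Cc1ccc(-c2ccccc2F)cc1`, has not yet been measured in this assay. It differs from compound 2 by 2-fluorophenyl in place of 3-fluorophenyl on an aromatic carbon: the same atoms are joined differently, so that the fluorine of the pendant ring moves to the 2-position, with the ring still sitting para to a large group on the core.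

Going by the values given here, no measured step bears directly on moving the fluorine within the pendant ring. Among the compounds with values here, the only step available, from compound 1 to compound 2, was within the scatter even though it exchanged a chloro for a whole fluorophenyl ring; a smaller rearrangement within that ring is therefore expected to give no change beyond the scatter in this assay, that is a step of a 1.0-fold lower number from compound 2 to compound 3 (0.00 log units; within the scatter). Compound 3 is accordingly estimated at 2500 nM, with a range from 800 nM to 8000 nM.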

Compound 3, inhibition constant: > 316 nM
Compound 3: only a limit was reported; the forecaster's own chance of this, stated with the estimate: 10%; the middle value does not contradict the limit.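

In this assay compound 3 gives > 316 nM, which is a limit of the assay and not a number. The steps to compound 3 from compound 1 and from compound 2 therefore cannot be read. The compounds shown leave open whether 2-fluorophenyl in place of 3-fluorophenyl changes the read-out at all, and in which direction.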